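The compounds below may be only part of what the source reports. "The series", "measured", "known", "first", "only" and "open" are said of these compounds alone.

Measured compounds in a functional assay on HT-29 cells (Homo sapiens) for cytotoxicity, read by MTT assay, with a stated time of 72 h; on this read-out higher numbers stand for weaker inhibition of growth and lower numbers for stronger inhibition of growth:
Compound 1 `COc1ccc(OC(=O)Nc2ccc([Se]C#N)cc2)cc1` — compound 1 gives 13600 nM
Compound 2 `CCCCCCOC(=O)Nc1ccc([Se]C#N)cc1` — compound 2 gives 10700 nM
Compound 3 `N#C[Se]c1ccc(NC(=O)Oc2ccc(F)cc2)cc1` — compound 3 gives 8800 nM

All three numbers lie within the scatter of one another; compound 3 sits at the low end of that cluster, with compound 2 nearest and compound 1 furthest from it, neither gap beyond the scatter.

Compound 4 `Cc1ccc(OC(=O)Nc2ccc([Se]C#N)cc2)cc1` is not yet measured. It differs from compound 3 in one place: methyl in place of fluoro on an aromatic carbon.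

Going by the values given here, one measured step bears on this position. Exchanging the substituent at the same place gave a 1.5-fold lower number from compound 1 to compound 3 (0.19 log units; within the scatter). Among the compounds with values here, that is the only comparison available for this site, and it did not move the number beyond the scatter. For the step to compound 4 no change beyond the scatter is therefore expected in this assay, and the expected step is a 1.1-fold higher number from compound 3 to compound 4 (0.03 log units; within the scatter).

The estimate for compound 4 is 9500 nM, with a range from 4500 nM to 20000 nM.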

Compound 4, concentration for 50% growth inhibition: 8800 nM
Compound 4: middle estimate off by 1.1-fold (0.03 log units), on the high side; low and high end bracket the measured number.
By their numbers in this assay, from the lowest: compounds 3, 4, 2 and 1 (each within the scatter of the next).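

In this assay the series shows no change at the digits printed from compound 3 to compound 4 (within the scatter) and a 1.5-fold lower number from compound 1 to compound 4 (0.19 log units; within the scatter) with methyl as a third group at the same place, on an aromatic carbon para to a large group. Where one exchange at this place could be read before, three groups can now be compared there, and the exchanges of fluoro and of methoxy for methyl both stay within the scatter. No data at hand speak to the cause of this flat picture.

On these data alone, whether any group at this place can move the number beyond the scatter remains open, since an amine, a carboxylic acid or a longer chain on this ring would be a much sharper test than these three. As far as these compounds go, whether the flat picture holds beyond this one cell line is also open.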